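Thiophene series: hydrazide to nitrile at the aromatic carbon

The source may report more compounds than this note shows. Statements on the series, on what has been measured and on what is new or still open speak of the compounds shown alone.

Compound 1 `NNC(=O)c1c(N)sc2c1CCN(Cc1ccccc1)C2` gives 8900 nM in an in vitro assay on CHOk1 cells with adenosine receptor A1 (Homo sapiens) as the target; on this read-out lower numbers stand for an effect already at smaller amounts and higher numbers for an effect only at larger amounts of compound. Compound 2 `CN1CCc2c(sc(N)c2C(=O)NN)C1` gives 4400 nM in this assay. Among the measured compounds shown here, the only measured step in the set, a 2.0-fold lower number from compound 1 to compound 2 (0.31 log units; beyond the scatter), concerns hydrogen in place of phenyl on the ring nitrogen; compound 2 therefore stands lowest of the two numbers, the nearest being compound 1.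

Compound 3 `CN1CCc2c(sc(N)c2C#N)C1` is not yet measured in this assay. Its difference from compound 2 is cyano in place of aminocarbamoyl on an aromatic carbon. For the measured compounds named here, no measured step touches this position, so no precedent within the set tells the size or direction of the change. Without such a step, the working expectation is no shift beyond the scatter for compound 3, i.e. an expected step of no change at the digits printed from compound 2 to compound 3 (within the scatter). Compound 3 is thus estimated at 4400 nM in this assay, within a range from 1300 nM to 15000 nM.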

Compound 3, half-maximal effective concentration: > 20000 nM
Compound 3: a limit, no number; the forecaster's own chance of this, stated with the estimate: 10%; middle value at least 4.5-fold (0.65 log units) from the limit.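

Among the compounds shown here, the aromatic carbon bearing aminocarbamoyl proves to be a position where the group matters in this assay: cyano in place of aminocarbamoyl gives an at least 4.5-fold higher number from compound 2 to compound 3 (0.65 log units; beyond the scatter), while the only earlier step, a 2.0-fold lower number from compound 1 to compound 2 (0.31 log units; beyond the scatter), lay at another place in the molecule. Compound 3 sits at a limit of the assay, not at a number: the limit of > 20000 nM in this assay, at which 1 of the 3 values shown sits. The step therefore has a floor but no known size, and the comparison of these two groups on this carbon rests on a single pair.

On these data alone, whether the terminal amino nitrogen or the carbonyl of aminocarbamoyl matters stays open; a primary carboxamide or a carboxylic acid on this carbon would separate the two. Also open, as far as these compounds go, is whether the same change holds with the phenyl of compound 1 in place.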